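Compound 3 to compound 4: 1,3-thiazol-2-yl for thiophen-2-yl

The source may report more compounds than this note shows. Statements on the series, on what has been measured and on what is new or still open speak of the compounds shown alone.

In a functional assay on 1A9 cells (Homo sapiens) for cytotoxicity (a lower number here means that less compound is needed, a higher number that more compound is needed for the effect), compound 1 (`COC1=C(C)C(=O)/C(=C(O)/C=C/c2cccc(OC)c2)C(=O)C1(C)C`) gives 2.9 ug/mL, compound 2 (`COC1=C(C)C(=O)/C(=C(O)/C=C/c2ccc(O)cc2)C(=O)C1(C)C`) gives 2.9 ug/mL and compound 3 (`COC1=C(C)C(=O)/C(=C(O)/C=C/c2cccs2)C(=O)C1(C)C`) gives 4 ug/mL. Compound 3 therefore stands within the scatter of both other compounds, and no order can be drawn among the three.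

Compound 4 (`COC1=C(C)C(=O)/C(=C(O)/C=C/c2nccs2)C(=O)C1(C)C`) carries 1,3-thiazol-2-yl in place of thiophen-2-yl on a double-bonded chain carbon bound to a double-bonded chain carbon.

Among the measured compounds shown here, no measured step makes this exact exchange. The closest evidence comes from the steps that change the group at the same place: no change at the digits printed from compound 1 to compound 2 (within the scatter), a 1.4-fold higher number from compound 1 to compound 3 (0.14 log units; within the scatter) and a 1.4-fold higher number from compound 2 to compound 3 (0.14 log units; within the scatter). For the measured compounds named here, all three are small, although this rests on only three compounds. A step beyond the scatter in this assay is therefore not expected, and no direction is favoured. The estimated step is a 1.1-fold lower number from compound 3 to compound 4 (0.06 log units; within the scatter), which is expected to stay within the scatter. Compound 4 is estimated at 3.5 ug/mL, with an expected range of 1.7 ug/mL to 7.5 ug/mL.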

Compound 4, concentration for half-maximal effect: 3.5 ug/mL
Compound 4: middle estimate and measured number agree at the digits printed; the measured number falls inside the stated range.
By their numbers in this assay, from the lowest: compounds 1, 2, 4 and 3 (each within the scatter of the next).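

In this assay a ring nitrogen enters the five-membered aromatic ring on a double-bonded chain carbon, with a 1.1-fold lower number from compound 3 to compound 4 (0.06 log units; within the scatter) as the result, so this position takes the added hydrogen-bond acceptor without a step beyond the scatter. The 1,3-thiazol-2-yl group also stays level with the two phenyl groups, with a 1.2-fold higher number from compound 2 to compound 4 (0.08 log units; within the scatter) and a 1.2-fold higher number from compound 1 to compound 4 (0.08 log units; within the scatter) as its steps from 4-hydroxyphenyl and 3-methoxyphenyl. No measurement at hand bears on why these aromatic groups read alike.

Open, as far as these compounds go, is whether an amine, a carboxylic acid or a longer chain at this place would move the number beyond the scatter. The four compounds share the rest of the core unchanged, so the effect of changes elsewhere on it cannot be read.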